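The source may hold more compounds than are shown below. What is called first, only, known or untested is meant among the compounds shown, and "the series" means these compounds.

Compound 1, `COC(=O)CNC(=O)c1ccc(OC[C@H]2COc3ccccc3O2)cc1-c1ccccc1OC`, and compound 2, `COC(=O)[C@H](CCSC)NC(=O)c1ccc(C(=O)NC[C@H]2COc3ccccc3O2)cc1-c1ccccc1OC`, were both tested in a functional assay (HSMC cells, Homo sapiens) for antiproliferative activity, with a stated time of 72 h; on this read-out lower numbers stand for stronger inhibition and higher numbers for weaker inhibition. Compound 1 gives 71000 nM; compound 2 gives 252000 nM, the higher of the two numbers and beyond the usual scatter from compound 1. Compound 3, `COC(=O)[C@H](CCSC)NC(=O)c1ccc(C(=O)NC[C@@H]2COc3ccccc3O2)cc1-c1ccccc1OC`, keeps every atom and bond of compound 2: the two compounds have the same atoms and bonds and differ only in configuration as drawn: 1 of 2 stereo elements differ; a stereocentre at a saturated ring carbon is drawn S in compound 2 and R in compound 3. Nothing measured here shows what such an inversion does in this assay, so no step beyond the scatter is expected in either direction. Compound 3 is therefore estimated at 220000 nM, within 60000 nM to 700000 nM, a step of a 1.1-fold lower number from compound 2 to compound 3 (0.06 log units; within the scatter).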

Compound 3, half-maximal inhibitory concentration: 647000 nM
Beside the measured number, compound 3's estimate is 2.9-fold (0.47 log units) below it; low and high end bracket the measured number.
By their numbers in this assay, from the lowest: compound 1; then compound 2; then compound 3.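

Inverting this saturated ring carbon changes the result in this assay: a 2.6-fold higher number from compound 2 to compound 3 (0.41 log units; beyond the scatter). Compound 1 and compound 2 differ in more than one place, so their gap could say nothing about this carbon on its own. This pair can isolate it, and the step can be assigned to the inversion because of what separates the two compounds: the fact that compounds 2 and 3 differ only in the configuration as drawn.

The compounds shown leave open whether the same inversion would matter with a carboxylic acid in place of the methyl ester. They also leave open what inverting the other stereocentre would do.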